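The source may hold more compounds than are shown below. What is called first, only, known or untested is meant among the compounds shown, and "the series" means these compounds.

Among the measured compounds shown here, in an ADME assay on HEp-2 cells (Homo sapiens) for cytotoxicity (on this read-out lower numbers stand for higher toxicity in this test and higher numbers for lower toxicity in this test), compound 3 `CC(C)c1ccccc1NC(=O)[C@@H]1CCCN1S(=O)(=O)c1cccc2cccnc12` gives 29900 nM, the only true number among the measured compounds. Compound 1 `Cc1ccc(NC(=O)CNS(=O)(=O)c2cccc3cccnc23)c(C)c1` returns only a limit, > 50000 nM. Compound 2 `Cc1ccc(NC(=O)C(C)NS(=O)(=O)c2cccc3cccnc23)c(C)c1` also returns only a limit, > 50000 nM. The remaining two values therefore sit at the limit of > 50000 nM in this assay, at which 2 of the 3 values shown sit.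

The next compound, compound 4 `Cc1cccc(C)c1NC(=O)[C@@H]1CCCN1S(=O)(=O)c1cccc2cccnc12`, differs from compound 3 as follows: 2,6-dimethylphenyl in place of 2-isopropylphenyl on an amide-type nitrogen. In short, 2,6-dimethylphenyl stands in place of 2-isopropylphenyl on an amide-type nitrogen.

For the measured compounds named here, the only measured step is a step that the two limits leave unreadable from compound 1 to compound 2. Going by the values given here, it concerns a different place in the structure, so no measured step bears on this change or gives it a size. With no measured guide, the number for compound 3, 29900 nM, remains the anchor, and no shift beyond the scatter is expected in this assay. The estimated change is a 1.3-fold higher number from compound 3 to compound 4 (0.13 log units; within the scatter). Compound 4 is expected at 40000 nM, with an estimated range from 20000 nM to 70000 nM, and the assay may report only a limit.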

Compound 4, half-maximal cytotoxic concentration: > 50000 nM
Compound 4 ended at the assay's limit; the forecaster's own chance of this, stated with the estimate: 45%; middle value at least 1.2-fold (0.09 log units) away from the limit.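

Among the compounds shown, 2,6-dimethylphenyl in place of 2-isopropylphenyl on the amide-type nitrogen gives the first step in this assay that can be read at all, and only as a floor: an at least 1.6-fold higher number from compound 3 to compound 4 (0.22 log units; that floor lies within the scatter). Compound 4 returns only a limit, > 50000 nM, so the step has no upper end, and its floor does not by itself separate the two groups. Among the compounds shown here, the change thus adds one more compound at the limit and leaves compound 3 as the only true number: the limit of > 50000 nM in this assay, at which 3 of the 4 values shown sit.

On these data alone, how far the true value of compound 4 lies from that limit stays open, and with it whether the two groups really differ in this test. Also open, as far as these compounds go, is whether an amine or a carboxylic acid on the aromatic ring at this position would give a readable number.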